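Chain end swap: compound 3 to compound 4

The source may report more compounds than this note shows. Statements on the series, on what has been measured and on what is new or still open speak of the compounds shown alone.

In a functional assay on HT-29 cells (Homo sapiens) for inhibition, read by luminescence and CellTiter-Glo, with a stated time of 24 h (a lower number here means that less compound is needed, a higher number that more compound is needed for the effect), compound 1 `CCn1nc(C(=O)N[C@H]2COc3ccccc3N(C)C2=S)nc1Cc1ccccc1` gives 17 nM, compound 2 `CN1C(=S)[C@@H](NC(=O)c2nc(Cc3ccccc3)n(CCC(F)(F)F)n2)COc2ccccc21` gives 1550 nM and compound 3 `CN1C(=S)[C@@H](NC(=O)c2nc(Cc3ccccc3)n(CCCC(F)(F)F)n2)COc2ccccc21` gives 2380 nM. Both a 91-fold higher number from compound 1 to compound 2 (1.96 log units; beyond the scatter) and a 140-fold higher number from compound 1 to compound 3 (2.15 log units; beyond the scatter) are large, while a 1.5-fold higher number from compound 2 to compound 3 (0.19 log units; within the scatter) stays within the scatter. Compound 3 therefore stands level with compound 2 and far from compound 1.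

Compound 4 `CN1C(=S)[C@@H](NC(=O)c2nc(Cc3ccccc3)n(CCCCCC#N)n2)COc2ccccc21` differs from compound 3 by 2-cyanoethyl in place of trifluoromethyl on a saturated chain carbon, three bonds along the chain from an aromatic nitrogen. The same difference, cut further out, reads 4,4,4-trifluorobutyl to 5-cyanopentyl. Among the compounds with values here, no measured step involves a nitrile, so the evidence is indirect. The nearest guide is a 1.5-fold higher number from compound 2 to compound 3 (0.19 log units; within the scatter), a change to a longer chain end that left the number within the scatter. The large 140-fold higher number from compound 1 to compound 3 (2.15 log units; beyond the scatter) suggests that compound 4 will not return to the level of compound 1. No step beyond the scatter is therefore expected in this assay, and no direction can be favoured. The expected step is a 1.2-fold lower number from compound 3 to compound 4 (0.08 log units; within the scatter). Compound 4 is estimated at 2000 nM, with an expected range of 400 nM to 8000 nM.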

Compound 4, half-maximal effective concentration: 3830 nM
Beside the measured number, compound 4's estimate is 1.9-fold (0.28 log units) below it; low and high end bracket the measured number.
By their numbers in this assay, from the lowest: compound 1; then compounds 2, 3 and 4 (each within the scatter of the next, the first and the last beyond it).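

In this assay the end of the chain tolerates a nitrile as much as a trifluoromethyl: a 1.6-fold higher number from compound 3 to compound 4 (0.21 log units; within the scatter) separates the 5-cyanopentyl chain from the 4,4,4-trifluorobutyl chain by no more than the scatter. Reading 3-cyanopropyl in place of trifluoromethyl, a 2.5-fold higher number from compound 2 to compound 4 (0.39 log units; beyond the scatter) is a modest step and the first beyond the scatter among the compounds with these longer chain ends. Within the data shown here, with a 230-fold higher number from compound 1 to compound 4 (2.35 log units; beyond the scatter) as the largest step so far, a chain end carrying a hydrogen-bond acceptor does not bring the number back towards that of compound 1.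

On these data alone, whether an amine or a carboxylic acid at the chain end, or a plain propyl chain, would narrow that gap remains open. Nothing available accounts for the size of these steps.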